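Methoxy in place of methyl on compound 1

The source may hold more compounds than are shown below. What is called first, only, known or untested is meant among the compounds shown, and "the series" means these compounds.

In a functional assay on HL-60 cells (Homo sapiens) for inhibition, read by MTT assay, with a stated time of 72 h (on this read-out higher numbers stand for weaker inhibition and lower numbers for stronger inhibition), compound 1 (`Cc1nc(-c2ccccc2F)c(C(=O)N2CCN(c3cc(Cl)ccc3C)CC2)o1`) stands at 229 nM and compound 2 (`Cc1nc(-c2ccccc2Cl)c(C(=O)N2CCN(c3cccc(Cl)c3)CC2)o1`) at 132 nM within the scatter of each other. Compound 3 (`COc1ccc(Cl)cc1N1CCN(C(=O)c2oc(C)nc2-c2ccccc2F)CC1`) keeps the core of compound 1 and carries methoxy in place of methyl on an aromatic carbon ortho to a large group and para to a chloro group. Going by the values given here, no measured pair shows this change alone. An estimated 1.1-fold lower number from compound 1 to compound 3 (0.06 log units; within the scatter) stays within the scatter in this assay with no firm direction expected. The estimated value for compound 3 is 200 nM with an expected range from 80 nM to 500 nM in this read-out.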

Compound 3, half-maximal inhibitory concentration: 153 nM
Estimate against measurement, compound 3: 1.3-fold (0.12 log units) above; measured number inside the range.
By their numbers in this assay, from the lowest: compounds 2, 3 and 1 (each within the scatter of the next).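

In this assay, going by these compounds alone, the first matched pair at this position gives a 1.5-fold lower number from compound 1 to compound 3 (0.18 log units; within the scatter) and so does not separate 5-chloro-2-methylphenyl from 5-chloro-2-methoxyphenyl. This position, ortho to a large group and para to a chloro group, thus takes methoxy in place of methyl, adding one hydrogen-bond acceptor by count, without a step beyond the scatter. No measurement at hand accounts for this result.

Going by these compounds, what an amine, a carboxylic acid or a longer chain such as ethoxy would do at this position remains open. So does whether the methoxy change reads the same without the chloro group.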